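This account rests on a few compounds, and the source may have more. Where it says the series, first, only, none or still open, it means among the compounds named here.

The measured compounds:
compound 1, `COc1cc(OC)c2cc(-c3ccc(OCc4ccccc4)cc3)c(O)nc2c1`, 10000 nM
compound 2, `COc1ccc(-c2cc3c(OC)cc(OC)cc3n(CC(=O)OCc3ccccc3)c2=O)cc1`, 10000 nM
compound 3, `COc1ccc(-c2cc3c(OC)cc(OC)cc3n(CC(=O)O)c2=O)cc1`, 10000 nM

All three were tested in a functional assay on T-24 cells (Homo sapiens) for cytotoxicity, read by colorimetric assay and MTT assay; a higher number here means a weaker inhibitor, a lower number a stronger inhibitor. In this assay compound 1 gives 10000 nM, compound 2 gives 10000 nM and compound 3 gives 10000 nM; the three values lie level within the usual scatter, so none of them can be set apart from the others.

Compound 2 and compound 3 differ in one place: hydrogen in place of benzyl on an oxygen next to a carbonyl group. That change made no change at the digits printed from compound 2 to compound 3 (within the scatter). Compound 1 shares much with compound 2, but the difference between the two cores is not broken down here.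

Compound 4, `COc1cc(OC)c2cc(-c3ccc(O)cc3)c(O)nc2c1`, has not been measured. It comes from compound 1 through (hydrogen in place of benzyl on an oxygen on an aromatic ring). Among the measured compounds shown here, this is the same kind of change as the one from compound 2 to compound 3, not the same one: in compound 2 the oxygen is next to a carbonyl group and its other neighbour is carbonyl carbon, whereas in compound 1 the oxygen is on an aromatic ring and its other neighbour is aromatic carbon. For the measured compounds named here, the one measured example of this kind of change left the read-out where it was, and compound 1 sits level with compound 2 and compound 3.

Compound 4 is therefore expected to show no change at the digits printed from compound 1 to compound 4 (within the scatter). This expectation rests on the earlier step, because no change at the digits printed from compound 2 to compound 3 (within the scatter) came from the same kind of change. The estimate for compound 4 is 10000 nM, with a likely range from 4000 nM to 25000 nM.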

Compound 4, half-maximal inhibitory concentration: 10000 nM
Estimate against measurement, compound 4: no gap at the digits printed; the measured number falls inside the stated range.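

Replacing benzyl with hydrogen on the oxygen on an aromatic ring gave no change at the digits printed from compound 1 to compound 4 (within the scatter) in this assay. Set beside the earlier step, in which the oxygen instead sits next to a carbonyl group, this kind of change gives matching results on the two cores: the same change on two cores in this assay, no change at the digits printed (within the scatter) from compound 2 to compound 3 and no change at the digits printed (within the scatter) from compound 1 to compound 4, 1.0-fold (0.00 log units) apart, within the scatter of two such steps. This shows that, for these two cores, carrying the change across left the read-out where it was, but it does not show that the change would be silent on other cores in the series, and it gives no case of the change on a compound that reads differently from these four, which all share one value.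

Still open, as far as these compounds go, is whether another group on that oxygen, such as a longer chain or a chain ending in an amine, or a carboxylic acid in place of the hydroxy group of compound 4, would read differently from these four compounds. Also open, from the compounds shown here alone, is whether a compound with a lower number on either core could be found and, if so, whether replacing benzyl with hydrogen would still leave its value unmoved.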